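Methyl-to-fluoro swap on two oxadiazole-linked cores

The compounds below may be only part of what the source reports. "The series", "measured", "known", "first", "only" and "open" are said of these compounds alone.

Measured compounds:
Compound 1 `COc1cc(C#N)ccc1OCc1nnc(-c2ccc(C)cc2)o1`: in a functional assay on MDA-MB-453 cells (Homo sapiens) for cytotoxicity, read by MTT assay, with a stated time of 48 h (a lower number here means a stronger inhibitor, a higher number a weaker inhibitor), compound 1 gives 38400 nM.
Compound 2 `COc1cc(C#N)ccc1OCc1nnc(-c2ccc(F)cc2)o1`: compound 2 gives 10500 nM.
Compound 3 `Cc1ccc(-c2nnc(COc3ccc(-c4nnco4)cc3)o2)cc1`: compound 3 gives > 50000 nM, which is a limit of this assay and not a number (the limit of > 50000 nM in this assay, at which 1 of the 3 values shown sits).

Compounds 1 and 2 share a core and differ in one place: fluoro in place of methyl on an aromatic carbon. That step reads a 3.7-fold lower number from compound 1 to compound 2 (0.56 log units; beyond the scatter). No cause for this step is given by the measurements made.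

Compound 3 carries a different core; how the core of compound 3 differs from the core of compound 1 is not broken down here. Compound 4 `Fc1ccc(-c2nnc(COc3ccc(-c4nnco4)cc3)o2)cc1` is not yet measured in this assay. It stands to compound 3 as compound 2 stands to compound 1: fluoro in place of methyl on an aromatic carbon. The place of the change is described in the same words for both pairs, so it is the same change made on a different core.

For the measured compounds named here, the only guide to compound 4 is the step from compound 1 to compound 2, together with the fact that compound 3 gives only a limit in this assay. A step of similar direction and size is expected, read off from a 3.7-fold lower number from compound 1 to compound 2 (0.56 log units; beyond the scatter), but with a limit as the starting point the result may itself remain a limit. The step expected from compound 3 is an at least 1.2-fold lower number from compound 3 to compound 4 (0.09 log units; that floor lies within the scatter). Compound 4 is estimated at 40000 nM, with a range from 12000 nM to 100000 nM, and a sizeable chance that this assay again reports only a limit.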

Compound 4, half-maximal inhibitory concentration: 38200 nM
The estimate for compound 4 lay 1.0-fold (0.02 log units) above the measured number; the range from low to high includes it.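

In this assay compound 3 gives > 50000 nM and that is a limit of the assay, not a number. The replacement of 4-methylphenyl by 4-fluorophenyl on this core therefore reads only as a floor, an at least 1.3-fold lower number from compound 3 to compound 4 (0.11 log units; that floor lies within the scatter) and this is compatible with a step like the one on the core of compound 1, but on its own it does not establish a real change on the core of compound 3. The two pairs show no reversal of direction, yet they do not show that the size of the step carries from one core to the other, and two pairs make no rule for the series: the same change on two cores in this assay, a 3.7-fold lower number (0.56 log units; beyond the scatter) from compound 1 to compound 2 and an at least 1.3-fold lower number (0.11 log units; that floor lies within the scatter) from compound 3 to compound 4; the limit leaves it open whether they differ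

Still open, as far as these compounds go, is how the step would read on the core of compound 3 if the methyl compound gave a number rather than a limit, and whether the same reading would hold on other cores. The compounds shown also leave open how other groups in the same place, such as a chloro, a trifluoromethyl or an amine, would compare with methyl and fluoro on either core.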